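This account rests on a few compounds, and the source may have more. Where it says the series, first, only, none or still open, it means among the compounds named here.

In a functional assay on FM3A cells (Mus musculus) for inhibition, read by cell counting, with a stated time of 2 days (on this read-out higher numbers stand for weaker inhibition and lower numbers for stronger inhibition), the three measured compounds stand as follows:

compound 1, `C=C(Br)C(=O)Nc1cccc(-c2cn3nc(Cc4ccccc4)sc3n2)c1`: 3000 nM
compound 2, `C=C(Br)C(=O)Nc1cccc(-c2cn3nc(-c4ccccc4)sc3n2)c1`: 900 nM
compound 3, `C=C(Br)C(=O)Nc1cccc(-c2cn3nc(-c4cccc(OC)c4)sc3n2)c1`: 500 nM

Compound 3 gives the lowest number of the three. Its separation from compound 2 is a 1.8-fold lower number from compound 2 to compound 3 (0.26 log units; within the scatter), so the two cannot be ordered against each other; its separation from compound 1 is a 6.0-fold lower number from compound 1 to compound 3 (0.78 log units; beyond the scatter), which is beyond the scatter. Compound 1 is also set apart from compound 2 by a 3.3-fold lower number from compound 1 to compound 2 (0.52 log units; beyond the scatter).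

Compound 4, `C=C(Br)C(=O)Nc1cccc(-c2cn3nc(-c4ccc(Cl)cc4)sc3n2)c1`, differs from compound 3 by 4-chlorophenyl in place of 3-methoxyphenyl on an aromatic carbon. Among the compounds with values here, the only measured step that bears on a change within the aryl ring itself is a 1.8-fold lower number from compound 2 to compound 3 (0.26 log units; within the scatter), and that lies within the scatter. The larger steps of a 3.3-fold lower number from compound 1 to compound 2 (0.52 log units; beyond the scatter) and a 6.0-fold lower number from compound 1 to compound 3 (0.78 log units; beyond the scatter) concern the exchange of benzyl for an aryl ring, a feature compound 4 keeps. Within the data shown here, no measured step involves a chlorine on that ring, so the direction of any effect cannot be read from the data. For compound 4 a step of no more than the usual scatter is expected, a 1.2-fold higher number from compound 3 to compound 4 (0.08 log units; within the scatter). Compound 4 is therefore estimated at 600 nM, with a range from 250 nM to 1500 nM.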

Compound 4, half-maximal inhibitory concentration: 2000 nM
Compound 4: middle estimate off by 3.3-fold (0.52 log units), on the low side; measured number above the stated range.
By their numbers in this assay, from the lowest: compounds 3 and 2 (each within the scatter of the next); then compounds 4 and 1 (each within the scatter of the next).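

In this assay, within the data shown here, the aryl ring at this position turns out to respond to what it carries: chloro in place of hydrogen gives a 2.2-fold higher number from compound 2 to compound 4 (0.35 log units; beyond the scatter) and is the first change on this ring to lie beyond the scatter, which methoxy in place of hydrogen did not do. The exchange of 3-methoxyphenyl for 4-chlorophenyl gives a 4.0-fold higher number from compound 3 to compound 4 (0.60 log units; beyond the scatter) and so shows that the two substituted rings are not interchangeable here, while 4-chlorophenyl in place of benzyl gives a 1.5-fold lower number from compound 1 to compound 4 (0.18 log units; within the scatter) and thus the advantage of the directly attached aryl ring over benzyl, seen with phenyl and 3-methoxyphenyl, does not appear with this ring. Nothing available accounts for the loss seen with 4-chlorophenyl.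

Among these compounds, the substituent and its place on the ring change together in this set, with chloro seen only in 4-chlorophenyl and methoxy only in 3-methoxyphenyl, so the contribution of each stays unresolved. Also open, as far as these compounds go, is how the ring at this position responds to other groups, such as an amine or a carboxylic acid.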